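The source may hold more compounds than are shown below. What is called first, only, known or untested is meant among the compounds shown, and "the series" means these compounds.

Going by the values given here, only two compounds have numbers so far in a physicochemical assay for solubility, in phosphate buffer, at pH 6.5 (a lower number here means a less soluble compound, a higher number a more soluble compound), and they differ in more than one place. Compound 1 (`CC(C)(C)c1ccccc1Oc1ncccc1NC(=O)Nc1ccc(-c2ccccc2CO)cc1F`) gives 2 ug/mL and stands lowest of the two. Compound 2 (`CC(C)(C)c1ccccc1Oc1ncccc1NC(=O)Nc1ccc(N2CCCCC2)cc1`) gives 9 ug/mL in the same test, a gap beyond the scatter.

Compound 3 (`CN(C)Cc1ccc(NC(=O)Nc2cccnc2Oc2ccccc2C(C)(C)C)c(F)c1`) has not yet been measured. It is compound 1 with (dimethylamino)methyl in place of 2-(hydroxymethyl)phenyl on an aromatic carbon, meta to a fluoro group and para to a large group ((dimethylamino)methyl in place of 2-(hydroxymethyl)phenyl on an aromatic carbon). What leaves carries a six-membered aromatic ring of carbon only, and what enters has no ring. Among the compounds with values here, no measured pair isolates this change, so the expectation rests on thin evidence. Compound 2, which also has no 2-(hydroxymethyl)phenyl, reads 9 ug/mL and offers only a loose hint of the direction. In this assay the expected step is upward and beyond the scatter, estimated at a 15-fold higher number from compound 1 to compound 3 (1.18 log units; beyond the scatter) for now. For compound 3 the estimated value is 30 ug/mL with an expected range from 8 ug/mL to 120 ug/mL once measured.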

Compound 3, solubility: 160 ug/mL
Compound 3: middle estimate off by 5.3-fold (0.73 log units), on the low side, and the stated range ends below it.
By their numbers in this assay, from the lowest: compound 1; then compound 2; then compound 3.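

In this assay, an 80-fold higher number from compound 1 to compound 3 (1.90 log units; beyond the scatter) comes with (dimethylamino)methyl in place of 2-(hydroxymethyl)phenyl, the first single-place change read in this series, and the step is large and beyond the scatter. It shows that this one aromatic carbon, meta to a fluoro group and para to a large group, can carry a large change in the read-out while the rest of compound 1 stays the same, and that a group with no ring and fewer heavy atoms is accepted there with the number moving upward. Nothing measured here bears on which part of the change produces the step.

The single swap removes the aromatic ring and the hydroxyl oxygen and brings in an amine nitrogen all at once, so the compounds shown do not separate these parts from one another. On these data alone, it remains open whether a plain methyl, a hydroxymethyl, a morpholine, a carboxylic acid or a longer chain such as 2-(dimethylamino)ethyl at this carbon would move the number as far, and whether a step of this size would hold with the fluoro group gone.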